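The source may report more compounds than this note shows. Statements on the series, on what has been measured and on what is new or still open speak of the compounds shown alone.

Compound 2 `CCC(C)OC(=O)C1=C(C)NC(=O)NC1c1ccoc1` gives 11% in an assay on membranes from HeLa cells for displacement of a labelled ligand from adenosine receptor A3 (Homo sapiens), read by scintillation counting, with a stated time of 180 min, tested at 1 uM (on this read-out lower numbers stand for less inhibition and higher numbers for more inhibition at the one concentration tested (going by the name of the read-out)), and stands beside compound 1 `CC1=C(C(=O)OCc2ccccc2)C(c2ccoc2)NC(=O)N1`, which gives 1%; the gap between them lies within the scatter. For the measured compounds named here, the only measured step at this oxygen, a number 10 percentage points higher from compound 1 to compound 2 (within the scatter), is therefore of no size that counts. Compound 3 `CC1=C(C(=O)OC2CCCC2)C(c2ccoc2)NC(=O)N1` differs from compound 2 by cyclopentyl in place of sec-butyl on an oxygen next to a carbonyl group. Since that one step at the same place stayed within the scatter, no movement beyond the scatter is expected in this assay for this further change of the ester group. The expected step is a number 1 percentage points higher from compound 2 to compound 3 (within the scatter). Compound 3 is estimated to give 12%, within a range of 0% to 30%.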

Compound 3, a percentage reported as inhibition, at one concentration (the size of the read-out at that concentration, not a potency): 1%
Compound 3: the middle estimate sits 11 percentage points above what was measured; low and high end bracket the measured number.
By their numbers in this assay, from the lowest: compounds 1, 3 and 2 (each within the scatter of the next).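

Cyclopentyl on an oxygen next to a carbonyl group gives a number 10 percentage points lower from compound 2 to compound 3 (within the scatter) in this assay, and in place of benzyl it gives no change at the digits printed from compound 1 to compound 3 (within the scatter) in the same read-out. Benzyl, sec-butyl and cyclopentyl therefore cannot be told apart at this position, whether the group has a ring or not. No evidence bears on this result. Still open, as far as these compounds go, is whether an ester group carrying an amine or a carboxylic acid, or a longer chain, would move the number beyond the scatter. Changes elsewhere on the shared core also remain open.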